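A few compounds are considered here, and "the series" means these few. Any claim that something is new, unique, unknown or untested is made for them only; others in the source may bear on it.

Measured in a functional assay on MOLT-4 cells (Homo sapiens) for inhibition, read by MTT assay, with a stated time of 72 h; on this read-out higher numbers stand for weaker inhibition and lower numbers for stronger inhibition:
compound 1 `COc1cc(NC(C)CCCNC(=O)NNC(=O)Nc2cc(C(F)(F)F)cc(C(F)(F)F)c2)c2ncccc2c1`, 22000 nM
compound 2 `COc1cc(NC(C)CCCNC(=O)Nc2ccc(C(F)(F)F)cc2)c2ncccc2c1`, 20000 nM
compound 3 `COc1cc(NC(C)CCCNC(=O)NNC(=O)Nc2ccc(C(F)(F)F)cc2)c2ncccc2c1`, 24000 nM

Compound 2 shows the lowest number of the three, but compound 1 and compound 3 both lie within the usual scatter of it, so the three are not told apart. Compound 4 `COc1cc(NC(C)CCCNC(=O)Nc2cccc(O)c2)c2ncccc2c1` is not yet measured. It differs from compound 2 by 3-hydroxyphenyl in place of 4-(trifluoromethyl)phenyl on an amide-type nitrogen. Within the data shown here, no measured pair shows this change, so its effect is unknown here. Given that the whole series sits close together in this assay, a step within the scatter, or at most a modest move toward weaker inhibition, is expected from compound 2 to compound 4, a 1.5-fold higher number from compound 2 to compound 4 (0.18 log units; within the scatter). Compound 4 is estimated at 30000 nM, with a range from 12000 nM to 80000 nM.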

Compound 4, half-maximal inhibitory concentration: 24000 nM
For compound 4 the middle estimate is 1.3-fold (0.10 log units) above the measured one; the measured number falls inside the stated range.
By their numbers in this assay, from the lowest: compounds 2, 1, 3 and 4 (each within the scatter of the next).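

Among these compounds, the first single-place comparison in this assay gives a 1.2-fold higher number from compound 2 to compound 4 (0.08 log units; within the scatter) when 3-hydroxyphenyl replaces 4-(trifluoromethyl)phenyl on the amide-type nitrogen. At this position, a smaller aryl group carrying a hydrogen-bond donor and acceptor is therefore not told apart from one carrying neither. No measured evidence bears on this result.

Still open, on these data alone, is whether an amine or a carboxylic acid on this ring would move the number beyond the scatter. The same question stands for a longer chain in place of the aryl group.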